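The source may report more compounds than this note shows. Statements on the series, on what has been measured and on what is new or still open speak of the compounds shown alone.

Measured compounds in a functional assay on SK-MEL-5 cells (Homo sapiens) for inhibition, read by sulforhodamine B assay, with a stated time of 48 h; on this read-out higher numbers stand for lower toxicity in this test and lower numbers for higher toxicity in this test:

compound 1 `O=C(Nc1cccc(-n2cc(-c3ccncc3)c(-c3ccc(Cl)c(O)c3)n2)c1)Nc1cccc(C(F)(F)F)c1` gives 13800 nM

compound 2 `COc1cc(-c2nn(-c3cccc(NC(=O)Nc4cc(C(F)(F)F)cc(C(F)(F)F)c4)c3)cc2-c2ccncc2)ccc1Cl` gives 2670 nM

Compound 2 has the lowest number of the two; compound 1 stands a good way higher in this assay, beyond the scatter. Compound 3 `O=C(Nc1cccc(-n2cc(-c3ccncc3)c(-c3ccc(Cl)c(O)c3)n2)c1)Nc1cc(C(F)(F)F)cc(C(F)(F)F)c1` differs from compound 2 by hydrogen in place of methyl on an oxygen on an aromatic ring, that is methoxy to hydroxy, so 4-chloro-3-methoxyphenyl becomes 4-chloro-3-hydroxyphenyl. Among the measured compounds shown here, no pair that isolates this change has been measured. Compound 1 carries the hydroxy group but also a different urea aryl, so it cannot serve as a guide. A step from compound 2 to compound 3 of modest size, direction uncertain, is expected: a 1.5-fold higher number from compound 2 to compound 3 (0.18 log units; within the scatter). Compound 3 is estimated at 4000 nM, within 1500 nM to 12000 nM.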

Compound 3, concentration lethal to 50% of the cells: 2620 nM
For compound 3 the middle estimate is 1.5-fold (0.18 log units) above the measured one; the measured number falls inside the stated range.
By their numbers in this assay, from the lowest: compounds 3 and 2 (each within the scatter of the next); then compound 1.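

In this assay, methoxy to hydroxy, now seen as an isolated change, gives a 1.0-fold lower number from compound 2 to compound 3 (0.01 log units; within the scatter), so the two groups read alike at this position. Trifluoromethyl in place of hydrogen on an aromatic carbon, also isolated here, gives a 5.3-fold lower number from compound 1 to compound 3 (0.72 log units; beyond the scatter), which makes this the only change shown with a step beyond the scatter. No evidence bears on either step.

As far as these compounds go, an amine or an ethoxy group at this position remains open. So does whether methoxy to hydroxy reads the same with the urea aryl of compound 1.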